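The source may hold more compounds than are shown below. What is called first, only, known or untested is meant among the compounds shown, and "the series" means these compounds.

In an ADME assay for permeability, using PAMPA, at pH 7.4 (a higher number here means that the compound crosses the layer faster, a lower number that the compound crosses the layer more slowly), compound 1 (`Cc1[nH]c2ccccc2c(=O)c1C1CCCCC1`) gives 230 10^-6 cm/s as the second highest of three numbers. Compound 2 (`Cc1nc2ccccc2c(OCc2ccccc2)c1Br`) stands higher at 794 10^-6 cm/s and compound 3 (`Cc1[nH]c2ccccc2c(=O)c1/C=C/c1ccc(O)cc1`) stands lower at 17 10^-6 cm/s with both gaps from compound 1 beyond the scatter. Compound 4 (`CCCCC#Cc1c(C)[nH]c2ccccc2c1=O`) carries hex-1-yn-1-yl in place of cyclohexyl on an aromatic carbon. Going by the values given here, no two measured compounds differ in one place only, so the data offer no direct guide to this change in this assay and the expectation stays anchored on compound 1 at 230 10^-6 cm/s as its reference. No step beyond the scatter is expected (a 1.2-fold lower number from compound 1 to compound 4 (0.06 log units; within the scatter)). Compound 4 is estimated at 200 10^-6 cm/s with an expected range from 70 10^-6 cm/s to 560 10^-6 cm/s in this measurement.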

Compound 4, apparent permeability: 2140 10^-6 cm/s
Beside the measured number, compound 4's estimate is 11-fold (1.03 log units) below it; the whole stated range lies below it.
By their numbers in this assay, from the lowest: compound 3; then compound 1; then compound 2; then compound 4.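

At this position, on an aromatic carbon of the shared core, hex-1-yn-1-yl in place of cyclohexyl gives a 9.3-fold higher number from compound 1 to compound 4 (0.97 log units; beyond the scatter) in this assay. The two groups match in their count of heavy atoms, and neither has a hydrogen-bond donor or acceptor, so those counts do not separate a step of this size. No measured evidence on the origin of this step is at hand. Still open, from the compounds shown here alone, is whether the step follows the triple bond or the open chain, which a saturated hexyl chain at this position would help to separate. Going by these compounds, how an amine would read there also remains open.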